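A chloro added on compound 3, before its reading

The compounds below may be only part of what the source reports. "The series", "measured", "known", "first", "only" and "open" are said of these compounds alone.

This account concerns a set of nitroimidazo-oxazine compounds that share one core. Compound 1 `C[C@]1(CN2CCc3oc(-c4ccc(F)c(F)c4)nc3C2)Cn2cc([N+](=O)[O-])nc2O1` and compound 2 `C[C@]1(CN2CCn3cc(-c4ccc(F)c(F)c4)nc3C2)Cn2cc([N+](=O)[O-])nc2O1` carry bicyclic side arms; in an ADME assay on Vero cells (Chlorocebus sabaeus) for cytotoxicity, read by MTT assay, with a stated time of 72 h (a higher number here means that more compound is tolerated, a lower number that less compound is tolerated), compound 1 gives "not determined" (no result reported), and compound 2 gives "not determined" (no result reported). Compound 3 `C[C@]1(CN2CCc3nc(-c4cccc(F)c4)ccc3C2)Cn2cc([N+](=O)[O-])nc2O1` carries a 3-fluorophenyl group. In this assay compound 3 reaches only a limit, > 32 ug/mL, so no single number stands for it; as the evidence shows, (the limit of > 32 ug/mL in this assay, at which 1 of the 3 values shown sits). Compound 3 therefore stands alone with a limit, while the other two entries offer no number at all.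

Compound 4 `C[C@]1(CN2CCc3nc(-c4cc(F)cc(Cl)c4)ccc3C2)Cn2cc([N+](=O)[O-])nc2O1` differs from compound 3 by chloro in place of hydrogen on an aromatic carbon. Going by the values given here, no step between measured compounds is available, so the size of this change in this assay is unknown; with compound 3 at the limit, an account would expect no step beyond the usual scatter. Compound 4 is therefore expected to show a step of a number no higher from compound 3 to compound 4 (the limit leaves the size open) from compound 3 to compound 4 in this assay. Compound 4 is estimated at 32 ug/mL, within a range from 16 ug/mL to 64 ug/mL.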

Compound 4, half-maximal cytotoxic concentration: > 32 ug/mL
Compound 4: a limit, no number; the forecaster's own chance of this, stated with the estimate: 70%; the middle value sits exactly at the limit.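

No step can be read from compound 3 to compound 4 in this assay, as each reading is only a limit and not a number. The compounds shown leave open whether chloro in place of hydrogen on an aromatic carbon changes this reading at all.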